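Swapping an Amide for Chlorine on the Pendant Ring

The compounds below may be only part of what the source reports. "The series", "measured", "known", "first", "only" and "open" are said of these compounds alone.

Compound 1 `NC(=O)c1cccc(Cn2cc(-c3ccc4cn[nH]c4c3)ccc2=O)c1` and compound 2 `NC(=O)c1ccccc1Cn1cc(-c2ccc3cn[nH]c3c2)ccc1=O` share the same core and differ only in where the carbamoyl group sits. In an assay for inhibition of MAP kinase-interacting serine/threonine-protein kinase 1 (Homo sapiens), read by luminescence and ADP-Glo, with a stated time of 2 h (on this read-out higher numbers stand for weaker inhibition and lower numbers for stronger inhibition), compound 1 gives 388 nM, and compound 2 gives 878 nM, so compound 1 holds the lower of the two numbers, with compound 2 beyond the scatter above it.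

Compound 3 `O=c1ccc(-c2ccc3cn[nH]c3c2)cn1Cc1cccc(Cl)c1` has not yet been measured. It differs from compound 1 by chloro in place of carbamoyl on an aromatic carbon. Going by the values given here, no measured pair shows an exchange of this kind, so there is nothing in the data to size the step directly. That moving the carbamoyl already shifts the number, as compound 1 with 388 nM against compound 2 with 878 nM shows, suggests the group is not inert. Removing it entirely is expected to weaken inhibition modestly, though the range is wide. For compound 3 the expected value is 850 nM, between 250 nM and 2800 nM, a step of a 2.2-fold higher number from compound 1 to compound 3 (0.34 log units; beyond the scatter).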

Compound 3, half-maximal inhibitory concentration: 37 nM
Compound 3: middle estimate off by 23-fold (1.36 log units), on the high side, and the stated range ends above it.
By their numbers in this assay, from the lowest: compound 3; then compound 1; then compound 2.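

In this assay, putting chloro in place of carbamoyl on this aromatic carbon gives a 10-fold lower number from compound 1 to compound 3 (1.02 log units; beyond the scatter), so inhibition here does not depend on keeping the carbamoyl group. The earlier pair only moved the carbamoyl to a different carbon of the pendant ring, so it could not show what another group does at this place; this step shows that the choice of group on this carbon can change the number strongly. Nothing measured here bears on why the number falls.

Still open, going by these compounds, is whether the step belongs to the arrival of chlorine or simply to the departure of carbamoyl: a plain hydrogen, a fluoro, a methyl or an amine on the same carbon would help separate the two. Also open, on these data alone, is whether chloro has a similar effect on the carbon that holds the carbamoyl in compound 2.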